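Swapping a Methoxyphenyl for a Furan Ring

This account rests on a few compounds, and the source may have more. Where it says the series, first, only, none or still open, it means among the compounds named here.

Of the compounds shown here, three measured so far share a core, differing at the ring that ends the double-bonded chain and at the amide side. Compound 1 `O=C(CO[N+](=O)[O-])Nc1ccc(C(=O)/C=C/c2ccco2)cc1` carries a furan at the chain end; in a functional assay on the whole organism (strain albino) for inhibition, with Rattus norvegicus as the target, read by paw edema, with stated times of 30 min and 1 h, at a dose of 100 mg/kg by the oral route (a higher number here means more inhibition at the dose given (going by the name of the read-out), a lower number less inhibition), compound 1 gives 34%. Compound 2 `CC(=O)c1ccc(OCC(=O)Nc2ccc(C(=O)/C=C/c3ccc(Cl)cc3)cc2)cc1` carries a chlorophenyl there and gives 43%. Among the compounds with values here, compound 3 `COc1ccc(/C=C/C(=O)c2ccc(NC(=O)COc3ccc(C(C)=O)cc3)cc2)cc1` carries a methoxyphenyl and gives 28%, the lowest of the three numbers, though its gap to compound 1 lies within the scatter; only the step of a number 15 percentage points lower from compound 2 to compound 3 (beyond the scatter) lies beyond it.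

Compound 4 `CC(=O)c1ccc(OCC(=O)Nc2ccc(C(=O)/C=C/c3ccco3)cc2)cc1` keeps the amide side of compound 3 and changes only the far ring: furan-2-yl in place of 4-methoxyphenyl on a double-bonded chain carbon bound to a double-bonded chain carbon. Within the data shown here, no measured step covers this exact exchange. Among the measured compounds shown here, the single measured step, a number 15 percentage points lower from compound 2 to compound 3 (beyond the scatter), shows that the far ring can move the number by a modest amount, and compound 1, the only furan-bearing compound, sits within the scatter of compound 3 while carrying a different amide side. A small rise is therefore expected, a number 7 percentage points higher from compound 3 to compound 4 (within the scatter), which may well stay inside the scatter. Compound 4 is expected to give 35%, estimated to lie between 22% and 48%.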

Compound 4, a percentage reported as inhibition, in the whole organism at one dose (the size of the read-out at that dose, not a potency): 28%
Compound 4: the middle estimate sits 7 percentage points above what was measured, and the stated range covers the measured number.
By their numbers in this assay, from the lowest: compounds 3, 4, 1 and 2 (each within the scatter of the next, the first and the last beyond it).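

In this assay, a five-membered furan-2-yl ring and a larger 4-methoxyphenyl ring at this place cannot be told apart, with no change at the digits printed from compound 3 to compound 4 (within the scatter), so the smaller ring count of heavy atoms brings no visible gain or loss here. The 4-chlorophenyl ring stands apart from both, as exchanging it for furan-2-yl gives a number 15 percentage points lower from compound 2 to compound 4 (beyond the scatter), a step of the same size as a number 15 percentage points lower from compound 2 to compound 3 (beyond the scatter), while with furan-2-yl kept at the chain end, 4-acetylphenyl in place of nitro on an oxygen on a saturated carbon gives a number 6 percentage points lower from compound 1 to compound 4 (within the scatter), so that exchange on the amide side leaves no reading beyond the scatter. No measurement offered here explains why the 4-chlorophenyl compound separates from the other two.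

The compounds shown leave open whether the separation belongs to chloro itself or would also appear with a bromo group, a trifluoromethyl group or an unsubstituted phenyl ring at this place. They also leave open how a thiophene ring or an amine on the far ring would read, and whether any of these rings would keep its place at another dose.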